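From Compound 3 to Compound 4: a Second Fluoro Group

The source may report more compounds than this note shows. Statements on the series, on what has been measured and on what is new or still open speak of the compounds shown alone.

Three compounds have been measured in a functional assay on J774 cells (Mus musculus) for cytotoxicity, read by resazurin assay, with a stated time of 72 h; a higher number here means a weaker inhibitor, a lower number a stronger inhibitor:
- compound 1 `O=S(=O)(Nc1cccc(CO)c1)c1ccc(-c2ccc(Cl)cc2)cc1` gives 2500 nM
- compound 2 `CN(C)c1ccc(-c2ccc(S(=O)(=O)Nc3cccc(CO)c3)cc2)cc1` gives > 5000 nM
- compound 3 `O=S(=O)(Nc1cccc(CO)c1)c1ccc(-c2ccccc2F)cc1` gives 1300 nM

The value for compound 2 is a limit of the assay, not a number (the limit of > 5000 nM in this assay, at which 1 of the 3 values shown sits). Among the two numbers, compound 3 stands lowest, with compound 1 nearest: a 1.9-fold lower number from compound 1 to compound 3 (0.28 log units; within the scatter), within the scatter. The step of an at least 3.8-fold lower number from compound 2 to compound 3 (0.58 log units; beyond the scatter) lies beyond the scatter, but rests on a limit.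

Compound 4 `O=S(=O)(Nc1cccc(CO)c1)c1ccc(-c2ccc(F)cc2F)cc1` differs from compound 3 in one place: fluoro in place of hydrogen on an aromatic carbon. Two measured steps change a substituent on the same ring. The step of a 1.9-fold lower number from compound 1 to compound 3 (0.28 log units; within the scatter) and the step of an at least 2.0-fold higher number from compound 1 to compound 2 (0.30 log units; that floor lies within the scatter) both fall at or near the scatter, so no step beyond the scatter is expected for this addition. For compound 4 in this assay the step is expected to be a 1.1-fold higher number from compound 3 to compound 4 (0.03 log units; within the scatter). The estimate for compound 4 is 1400 nM, in the range 600 nM to 3200 nM.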

Compound 4, half-maximal inhibitory concentration: 300 nM
For compound 4 the middle estimate is 4.7-fold (0.67 log units) above the measured one; measured number outside the range, below it.
By their numbers in this assay, from the lowest: compound 4; then compounds 3 and 1 (each within the scatter of the next). At a limit, above all of these: compound 2.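

In this assay, going by these compounds alone, a single fluoro, para to a large group and meta to a fluoro group, gives a 4.3-fold lower number from compound 3 to compound 4 (0.64 log units; beyond the scatter) and so moves the number at this position, where the earlier steps beyond the scatter rested only on a limit. The 2,4-difluorophenyl in place of 4-chlorophenyl gives an 8.3-fold lower number from compound 1 to compound 4 (0.92 log units; beyond the scatter) and, in place of 4-(dimethylamino)phenyl, gives an at least 16-fold lower number from compound 2 to compound 4 (1.22 log units; beyond the scatter) on the same ring. The value for compound 2 is a limit and not a number: the limit of > 5000 nM in this assay, at which 1 of the 4 values shown sits.

The compounds shown leave open whether fluoro is particular at this place or whether a chloro, a methoxy or a nitrile there would give a like step. They also leave open what this fluoro does on a phenyl ring without the 2-fluoro group.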